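Cyano for bromo on the terminal aryl ring

The source may hold more compounds than are shown below. What is called first, only, known or untested is meant among the compounds shown, and "the series" means these compounds.

The series keeps the core of compound 1 `CNC(=O)c1cc(Oc2ccc(C(=O)/C=C/c3ccc(Cl)c(Cl)c3)cc2)ccn1` and varies the aryl group on the double-bonded chain carbon. In a functional assay on MCF7 cells (Homo sapiens) for cytotoxicity, read by MTT assay, with a stated time of 72 h (a lower number here means a stronger inhibitor, a higher number a weaker inhibitor), compound 1 gives 13200 nM. Compound 2 `CNC(=O)c1cc(Oc2ccc(C(=O)/C=C/c3ccc(OC)c(OC)c3OC)cc2)ccn1` gives 2910 nM in this assay. Compound 3 `CNC(=O)c1cc(Oc2ccc(C(=O)/C=C/c3ccc(Br)cc3)cc2)ccn1` reaches only a limit of the assay in this assay, > 50000 nM. Compound 3 therefore stands at the top of the numbers shown: the step of an at least 3.7-fold higher number from compound 1 to compound 3 (0.57 log units; beyond the scatter) is beyond the scatter, and the value of compound 2 sits below the limit of compound 3, while the limit of > 50000 nM in this assay, at which 1 of the 3 values shown sits, caps what can be said about compound 3 itself.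

Compound 4 `CNC(=O)c1cc(Oc2ccc(C(=O)/C=C/c3ccc(C#N)cc3)cc2)ccn1` differs from compound 3 by cyano in place of bromo on an aromatic carbon. Among the compounds with values here, no measured step exchanges one group for another at that position, so nothing directly gauges this change; the only measured step, an at least 3.7-fold higher number from compound 1 to compound 3 (0.57 log units; beyond the scatter), concerns a different pair of aryl groups and shows merely that compound 3 is a weak point from which a move in either direction remains possible. Since compound 3 gives only a limit, the starting number is itself unknown, and any expected step is uncertain. The expected step is an at least 1.6-fold lower number from compound 3 to compound 4 (0.22 log units; that floor lies within the scatter). Compound 4 is estimated at 30000 nM, with a range from 5000 nM to 100000 nM, and a fair chance that only a limit is again reported.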

Compound 4, half-maximal inhibitory concentration: 9520 nM
Compound 4: middle estimate off by 3.2-fold (0.50 log units), on the high side; the range from low to high includes it.
By their numbers in this assay, from the lowest: compound 2; then compounds 4 and 1 (each within the scatter of the next). At a limit, above all of these: compound 3.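

In this assay, within the data shown here, cyano in place of bromo, on the aromatic carbon para to a large group, gives an at least 5.2-fold lower number from compound 3 to compound 4 (0.72 log units; beyond the scatter); this is the first measured exchange of one group for another at this position, and it shows that the outcome depends on which single group sits there. The 4-cyanophenyl compound also cannot be told apart from the 3,4-dichlorophenyl compound, as the step reads a 1.4-fold lower number from compound 1 to compound 4 (0.14 log units; within the scatter), so the weak result of compound 3 does not mean that one group on this ring falls short of two. The size of the gain from compound 3 has only a floor, since compound 3 is held at a limit: the limit of > 50000 nM in this assay, at which 1 of the 4 values shown sits.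

On these data alone, with only cyano and bromo compared at this position, it remains open whether an amine, a carboxylic acid or a single methoxy there would leave the number where compound 4 stands or bring it towards compound 2 at 2910 nM. Also open, as far as these compounds go, is whether the exchange of bromo for cyano would give a comparable step on a ring that carries further groups, such as the 3,4-dichlorophenyl ring of compound 1.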